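Fluoro substitution on the shared core: working notes

The source may hold more compounds than are shown below. What is called first, only, known or untested is meant among the compounds shown, and "the series" means these compounds.

Measured in an assay on HepG2 cells for activation of nuclear factor erythroid 2-related factor 2 (Homo sapiens), read by a luciferase reporter, with a stated time of 5 h; a higher number here means that more compound is needed for the effect, a lower number that less compound is needed:
compound 1, `Cc1ccc(/C=C/c2ccccc2F)cc1`: 1400 nM
compound 3, `Fc1ccc(F)c(/C=C/c2ccccc2F)c1`: 5900 nM
compound 2, `Fc1cccc(/C=C/c2ccccc2F)c1`: only a limit of the assay, > 15000 nM

Of the two numbers, compound 1 has the lower, and its gap to compound 3 is beyond the scatter. Compound 2 gives no number in this assay but a limit. From compound 2 to compound 3 the change is fluoro in place of hydrogen on an aromatic carbon; it produces an at least 2.5-fold lower number from compound 2 to compound 3 (0.40 log units; beyond the scatter). The size of that step is known only as a bound because compound 2 sits at the limit of > 15000 nM in this assay, at which 1 of the 3 values shown sits.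

The cores of compound 1 and compound 2 differ in more than one place; that difference is not broken down here.

Compound 4, `Cc1ccc(/C=C/c2ccc(F)cc2F)cc1`, is not yet measured. It differs from compound 1 by fluoro in place of hydrogen on an aromatic carbon. This is the same kind of change as that from compound 2 to compound 3, not the same change: there the entering fluoro is ortho to a group of 9 heavy atoms and para to a fluoro group, here it is meta to a fluoro group and para to a group of 9 heavy atoms.

In this assay compound 4 is expected to give a 1.6-fold lower number from compound 1 to compound 4 (0.19 log units; within the scatter). This expectation rests on compound 1 at 1400 nM and on the size of the measured step, an at least 2.5-fold lower number from compound 2 to compound 3 (0.40 log units; beyond the scatter), with the differing place taken as a reason for a smaller step. The estimate for compound 4 is 900 nM, expected between 400 nM and 2500 nM.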

Compound 4, half-maximal effective concentration: 2000 nM
The estimate for compound 4 lay 2.2-fold (0.35 log units) below the measured number; the range from low to high includes it.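

In this assay, fluoro in place of hydrogen on an aromatic carbon, meta to a fluoro group and para to a group of 9 heavy atoms, gives a 1.4-fold higher number from compound 1 to compound 4 (0.15 log units; within the scatter), so on the core of compound 1 this step cannot be told apart from repeat measurement. The same kind of change therefore does not carry over at a fixed size between the two cores: the same change on two cores in this assay, an at least 2.5-fold lower number (0.40 log units; beyond the scatter) from compound 2 to compound 3 and a 1.4-fold higher number (0.15 log units; within the scatter) from compound 1 to compound 4, at least 3.6-fold (0.56 log units) apart, beyond the scatter of two such steps This does not show that the core alone sets the size of the step, as the two steps differ both in the core and in the place of the entering fluoro, and the earlier step is known only as a bound: the limit of > 15000 nM in this assay, at which 1 of the 4 values shown sits.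

Open is whether fluoro at one and the same place would give matching steps on the core of compound 1 and the core of compound 2, as the two steps shown offer no such matched pair. Also open is whether an amine, a carboxylic acid or a longer chain entering at the place taken by fluoro in compound 4 would give a step beyond the scatter, as fluoro is the only group entering in the steps shown.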